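Ring enlargement on the amide of compound 3

A few compounds are considered here, and "the series" means these few. Any claim that something is new, unique, unknown or untested is made for them only; others in the source may bear on it.

Of the compounds shown here, three sharing one core have been measured in a functional assay on the whole organism (strain Wistar) for inhibition, with Rattus norvegicus as the target, read by paw edema, with stated times of 60 min and 6 h, at a dose of 100 mg/kg by the oral route; a higher number here means more inhibition at the dose given (going by the name of the read-out), a lower number less inhibition. Compound 1 `COc1cc2c(cc1OC)C(CC(N)=O)CC2` gives 27.8%, compound 2 `CCNC(=O)CC1CCc2cc(OC)c(OC)cc21` gives 20.4%, and compound 3 `COc1cc2c(cc1OC)C(CC(=O)N1CCCC1)CC2` gives 22.2%. All three numbers lie within the scatter of one another: the step of a number 5.6 percentage points lower from compound 1 to compound 3 (within the scatter) and the step of a number 1.8 percentage points higher from compound 2 to compound 3 (within the scatter) are both small, as is the step of a number 7.4 percentage points lower from compound 1 to compound 2 (within the scatter), so nothing beyond chance separates compound 3 from either neighbour.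

Compound 4 `COc1cc2c(cc1OC)C(CC(=O)N1CCCCC1)CC2` has not yet been measured. It differs from compound 3 in one place: piperidin-1-yl in place of pyrrolidin-1-yl on a carbonyl carbon.

For the measured compounds named here, the steps that bear on this change are the two that already vary the group on the carbonyl carbon while keeping the rest of the molecule fixed. The step of a number 5.6 percentage points lower from compound 1 to compound 3 (within the scatter) exchanged a small group for the five-membered ring, and the step of a number 1.8 percentage points higher from compound 2 to compound 3 (within the scatter) exchanged a chain for that same ring; neither moved the paw edema inhibition beyond the scatter. A further exchange of one saturated ring for a slightly larger one is therefore expected to leave the number where it is, with the expected step of a number 0.2 percentage points lower from compound 3 to compound 4 (within the scatter) lying inside the scatter. The value of compound 4 is estimated at 22%, within a range from 12% to 32%.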

Compound 4, a percentage reported as inhibition, in the whole organism at one dose (the size of the read-out at that dose, not a potency): 31.5%
Compound 4: middle estimate off by 9.5 percentage points, on the low side; low and high end bracket the measured number.
By their numbers in this assay, from the lowest: compounds 2, 3, 1 and 4 (each within the scatter of the next, the first and the last beyond it).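

In this assay, for the compounds shown here, the exchange of ethylamino for piperidin-1-yl on a carbonyl carbon gives the first step at this position that passes the scatter, a number 11.1 percentage points higher from compound 2 to compound 4 (beyond the scatter), which shows that the group held there can separate two compounds, if only modestly. Going by these compounds alone, the ring enlargement itself, a number 9.3 percentage points higher from compound 3 to compound 4 (within the scatter), and the exchange of amino for piperidin-1-yl, a number 3.7 percentage points higher from compound 1 to compound 4 (within the scatter), both stay inside the scatter, so the six-membered ring cannot be told apart from the five-membered ring or from the plain amide, and the single step beyond the scatter does not make a trend. Nothing available on these compounds bears on why compound 4 parts from compound 2.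

The compounds shown leave open whether a seven-membered azepan-1-yl ring, or a morpholin-4-yl ring with its added oxygen atom, on the same carbonyl carbon would give a number nearer that of compound 4 or that of compound 2. They also leave open whether any of these differences would hold at another dose, since each number here is the size of the effect at one dose and not a potency.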